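Shortening the Alkyl Chain From Compound 3 to Compound 4

This account rests on a few compounds, and the source may have more. Where it says the series, first, only, none or still open, it means among the compounds named here.

Compound 1 `CCCCCCCCCCCCCCCCOP(=O)(O)OCCSC(=S)N1CCCCCC1` gives 17600 nM in a functional assay on DU-145 cells (Homo sapiens) for inhibition, read by MTT assay, with stated times of 18 h and 4 h; on this read-out higher numbers stand for weaker inhibition and lower numbers for stronger inhibition. Compound 3 `CCCCCCCCOP(=O)(O)OCCSC(=S)N1CCCCCC1` gives 59100 nM in this assay. Compound 2 `CCCCCCCCOP(=O)(O)OCCSC(=S)N1CCCCC1` reaches only a limit of this assay, > 100000 nM (the limit of > 100000 nM in this assay, at which 1 of the 3 values shown sits).

Of the two numbers shown, compound 3 stands highest, with compound 1 as its nearest neighbour, separated by the step of a 3.4-fold higher number from compound 1 to compound 3 (0.53 log units; beyond the scatter). Compound 4 `CCCOP(=O)(O)OCCSC(=S)N1CCCCCC1` differs from compound 3 in one place: hydrogen in place of pentyl on a saturated chain carbon, three bonds along the chain from an oxygen on an unsaturated carbon. Among the compounds with values here, only the step from compound 1 to compound 3 bears on this change, and since it already raised the number beyond the scatter, a further rise of similar size is expected, a 2.5-fold higher number from compound 3 to compound 4 (0.40 log units; beyond the scatter). Compound 4 is therefore estimated at 150000 nM, between 60000 nM and 400000 nM, and it may well come back as a limit rather than a number.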

Compound 4, half-maximal inhibitory concentration: 86100 nM
The estimate for compound 4 lay 1.7-fold (0.24 log units) above the measured number, within the range that was stated.
By their numbers in this assay, from the lowest: compound 1; then compounds 3 and 4 (each within the scatter of the next). At a limit, above all of these: compound 2.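

In this assay, going from octyl to propyl gives a 1.5-fold higher number from compound 3 to compound 4 (0.16 log units; within the scatter) and so cannot be told apart from repeat measurement. The earlier cut, from hexadecyl to octyl, gave a 3.4-fold higher number from compound 1 to compound 3 (0.53 log units; beyond the scatter) and did lie beyond the scatter, so among these three compounds, removing chain carbons does not have the same effect at every length. Nothing measured here explains why the two steps differ.

As far as these compounds go, whether a methyl or ethyl chain would stay within the scatter of compound 4 remains open. So does the effect of an amine or a carboxylic acid at the end of the propyl chain.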